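The source may hold more compounds than are shown below. What is called first, only, known or untested is meant among the compounds shown, and "the series" means these compounds.

Working notes on the series in an assay on isolated protein with Bile acid receptor (Homo sapiens) as the target; on this read-out higher numbers stand for an effect only at larger amounts of compound and lower numbers for an effect already at smaller amounts. Of the compounds shown here, two carry measured numbers so far. Compound 1 `COC(=O)/C=C/c1cccc(N(Cc2ccc(/C=C/c3ccc(F)cc3)cc2)C(=O)NC(C)C)c1` gives 348 nM in this assay. Compound 2 `COC(=O)/C=C/c1cccc(N(Cc2ccc(-c3cccc(C)c3)cc2)C(=O)C(C)C)c1` gives 163 nM in this assay, the lower of the two numbers, and its gap to compound 1 lies beyond the usual scatter. Compounds 1 and 2 differ in more than one place, so no single structural step can be read from that gap.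

Compound 3 `COC(=O)/C=C/c1cccc(N(Cc2ccc(-c3cccc(C)c3)cc2)C(=O)NC(C)C)c1` is not yet measured. It differs from compound 2 by isopropylamino in place of isopropyl on a carbonyl carbon. Among the compounds with values here, no measured pair isolates this change. Compound 1 also carries the isopropylamino on the carbonyl carbon, but it differs from compound 2 in a second place as well, so its number cannot be attributed to this change alone. The expected step is therefore a 1.2-fold higher number from compound 2 to compound 3 (0.09 log units; within the scatter), that is, no shift beyond the scatter in either direction, with a modest loss held possible. Compound 3 is accordingly estimated at 200 nM, with a range from 70 nM to 600 nM.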

Compound 3, half-maximal effective concentration: 1330 nM
Beside the measured number, compound 3's estimate is 6.7-fold (0.82 log units) below it, and the stated range ends below it.
By their numbers in this assay, from the lowest: compound 2; then compound 1; then compound 3.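

On the carbonyl carbon whose other neighbours are the amide-type nitrogen, the change from isopropylcarbonyl to isopropylcarbamoyl is now isolated with the 3-methylphenyl group held constant, and in this assay it gives an 8.2-fold higher number from compound 2 to compound 3 (0.91 log units; beyond the scatter), so this position is sensitive to the swap of isopropyl for isopropylamino. With the isopropylamino on the carbonyl carbon held constant, the group on the aromatic carbon also moves the number: 3-methylphenyl in place of 2-(4-fluorophenyl)ethenyl gives a 3.8-fold higher number from compound 1 to compound 3 (0.58 log units; beyond the scatter), so the 3-methylphenyl group does not offer an advantage in the isopropylamino setting. Nothing at hand gives a reason for either step.

It remains open whether the step on the carbonyl carbon keeps its size with 2-(4-fluorophenyl)ethenyl on the aromatic carbon; the compounds shown hold no isopropyl partner for compound 1, so the two changes cannot be tested for independence. Also open, going by these compounds, is how a cyclopropyl, a methoxy or a dimethylamino group would read on the same carbonyl carbon, and how a carboxylic acid would read in place of the methyl ester.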